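Methylsulfanyl in Place of Chloro: an Expected Cytotoxicity

The source may report more compounds than this note shows. Statements on the series, on what has been measured and on what is new or still open speak of the compounds shown alone.

Measured so far:
Compound 1 (`Nc1nc(Cl)c2ncn(C3CC(CO)C(O)C3O)c2n1`) reaches in a functional assay on cells (Cancer cell lines, Homo sapiens) for cytotoxicity (on this read-out higher numbers stand for an effect only at larger amounts of compound and lower numbers for an effect already at smaller amounts), only a limit, > 100 ug/mL.
Compound 2 (`Nc1nc(Cl)c2nnn(C3CC(CO)C(O)C3O)c2n1`) gives in this assay a value of 8 ug/mL.

Going by the values given here, compound 2 thus stands as the only real number in this set. The other result, that of compound 1, is a limit of > 100 ug/mL in this assay, at which 1 of the 2 values shown sits, and not a measured value, so the two cannot be compared beyond saying that one is a number and one is not.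

Compound 3 (`CSc1nc(N)nc2c1nnn2C1CC(CO)C(O)C1O`) has not been tested. It differs from compound 2 by methylsulfanyl in place of chloro on an aromatic carbon. Among the compounds with values here, no measured pair shows this change, so the step is estimated: a modest weakening in this assay, close to the edge of scatter, is expected, a 2.5-fold higher number from compound 2 to compound 3 (0.40 log units; beyond the scatter). Compound 3 is therefore expected at 20 ug/mL, with a range from 6 ug/mL to 70 ug/mL.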

Compound 3, concentration for half-maximal effect: > 100 ug/mL
Compound 3: only a limit was reported (the forecaster's own chance of this, stated with the estimate: 20%); middle value at least 5.0-fold (0.69 log units) from the limit.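

In this assay, replacing chloro with methylsulfanyl on this aromatic carbon, next to the ring nitrogen, gives an at least 12-fold higher number from compound 2 to compound 3 (1.09 log units; beyond the scatter), so this position does not accept the change without a large loss of effect. From the compounds shown here alone, compound 3 gives only a limit, > 100 ug/mL, so the true size of the step remains unknown and could be larger than the printed figure. Within this single comparison, the measurable cytotoxicity therefore depends on keeping chloro at this position, and compound 2 remains the only compound with a real number: the limit of > 100 ug/mL in this assay, at which 2 of the 3 values shown sit.

A single replacement cannot show whether other groups on this carbon, such as an amine, a methoxy group or a bromo group, would keep the effect. It also leaves open how methylsulfanyl would behave on the core of compound 1.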